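A few compounds are considered here, and "the series" means these few. Any claim that something is new, unique, unknown or untested is made for them only; others in the source may bear on it.

Compound 1 `CCCCC[Se]c1nc(N)c2ccccc2n1` is known in a functional assay on HT-29 cells (Homo sapiens) for cytotoxicity, read by MTT assay, with a stated time of 72 h (a higher number here means a weaker inhibitor of growth, a lower number a stronger inhibitor of growth), only by a limit: compound 1 gives > 100000 nM. Compound 2 `CCCCC[Se]c1nc([Se]CCCCC)c2ccccc2n1` likewise returns a limit, > 100000 nM. The step that the two limits leave unreadable from compound 1 to compound 2 therefore cannot be read, since both values sit at the limit of > 100000 nM in this assay, at which 2 of the 2 values shown sit. Compound 3 `Nc1nc([SeH])nc2ccccc12` differs from compound 1 by hydrogen in place of pentyl on a selenium. Within the data shown here, no measured step bears on this change, and compound 1 offers only a limit, so the expectation rests on that limit alone. Compound 3 is expected to give 100000 nM, between 20000 nM and 300000 nM. The step of a number no higher from compound 1 to compound 3 (the limit leaves the size open) is thus expected to stay within the scatter.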

Compound 3, concentration for total growth inhibition: > 100000 nM
Compound 3 gave a limit, no number (the forecaster's own chance of this, stated with the estimate: 70%); the middle value lies on the limit itself.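

Among these compounds, compound 1 and compound 3 are both known only by limits, so no step between them can be read: the limit of > 100000 nM in this assay, at which 3 of the 3 values shown sit. The compounds shown leave open how far any change on the shared core shifts the result in this assay below that limit.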